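This account rests on a few compounds, and the source may have more. Where it says the series, first, only, none or still open, it means among the compounds named here.

Compound 1 `COc1ccc(-c2cn3ccnc3c(-c3ccc4ncn(C5CCCCC5)c4c3)n2)cc1` gives 80.9% in a functional assay on U-251 cells (Homo sapiens) for inhibition, read by sulforhodamine B assay, with a stated time of 48 h, tested at 10 uM; on this read-out lower numbers stand for less inhibition and higher numbers for more inhibition at the one concentration tested (going by the name of the read-out); compound 2 `O=Cc1ccc(-c2cn3ccnc3c(-c3ccc4ncn(C5CCCCC5)c4c3)n2)cc1` gives 32% in this assay.

Among the compounds with values here, compound 2 stands lowest of the two numbers measured so far; its only neighbour is compound 1, and the single recorded step, a number 48.9 percentage points lower from compound 1 to compound 2 (beyond the scatter), separates them. Compound 3 `CC(=O)c1ccc(-c2cn3ccnc3c(-c3ccc4ncn(C5CCCCC5)c4c3)n2)cc1` is the next member of this series, and the change from compound 2 to compound 3 is methyl in place of hydrogen on a carbonyl carbon, which cut one bond further out reads formyl to acetyl. Within the data shown here, no measured step bears directly on this change: the one step known swaps the whole group on that aromatic carbon, formyl for methoxy, rather than extending the carbonyl. The size of the step in this assay therefore cannot be read from the data, and the expectation defaults to none beyond the scatter, with wide uncertainty. Compound 3 is thus expected to give 36%, in a range from 14% to 62%, which means an expected step of a number 4 percentage points higher from compound 2 to compound 3 (within the scatter).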

Compound 3, a percentage reported as inhibition, at one concentration (the size of the read-out at that concentration, not a potency): 3.02%
For compound 3 the middle estimate is 33 percentage points above the measured one, outside the stated range (below it).
By their numbers in this assay, from the lowest: compound 3; then compound 2; then compound 1.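

In this assay, methyl in place of hydrogen on the carbonyl carbon brings a number 29 percentage points lower from compound 2 to compound 3 (beyond the scatter), so even this one added carbon on the carbonyl carries a change beyond the scatter. Acetyl in place of methoxy on the aromatic carbon brings a number 77.9 percentage points lower from compound 1 to compound 3 (beyond the scatter), a larger fall than the one for formyl in place of methoxy, a number 48.9 percentage points lower from compound 1 to compound 2 (beyond the scatter), and among these three compounds both carbonyl groups stand under methoxy. Nothing available here explains either step.

The compounds shown leave open whether a longer chain on the carbonyl, such as propanoyl, would continue this fall. They also leave open how a carboxylic acid or an amide on the same aromatic carbon would compare with formyl, acetyl and methoxy.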